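The source may report more compounds than this note shows. Statements on the series, on what has been measured and on what is new or still open speak of the compounds shown alone.

Measured so far:
compound 1, `COC(=O)C[C@H](NC(=O)OC(C)(C)C)C(=O)NC1(C(=O)NCc2ccccc2)CCN(Cc2ccccc2)CC1`: 24000 nM
compound 2, `COC(=O)C[C@H](NC(=O)OC(C)(C)C)C(=O)N(C)C1(C(=O)NCc2ccccc2)CCN(Cc2ccccc2)CC1`: 11000 nM
compound 3, `CC(C)(C)OC(=O)N[C@@H](CC(N)=O)C(=O)N(Cc1ccccc1)C1(C(=O)NCc2ccccc2)CCN(Cc2ccccc2)CC1`: 25000 nM

All three were tested in a functional assay on HeLa cells (Homo sapiens) for inhibition, with a stated time of 72 h; on this read-out higher numbers stand for weaker inhibition and lower numbers for stronger inhibition. Compound 1 gives 24000 nM there, and compound 2, which carries methyl in place of hydrogen on an amide-type nitrogen, gives 11000 nM; the step is a 2.2-fold lower number from compound 1 to compound 2 (0.34 log units; beyond the scatter). Compound 3 gives 25000 nM, and its value lies within the scatter of that of compound 1, so nothing separates the two. The difference between the core of compound 3 and the core of compound 1 is not broken down here.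

Compound 4, `CNC(=O)C[C@H](NC(=O)OC(C)(C)C)C(=O)N(Cc1ccccc1)C1(C(=O)NCc2ccccc2)CCN(Cc2ccccc2)CC1`, has not yet been measured in this assay. It differs from compound 3 by methyl in place of hydrogen on an amide-type nitrogen. This is the same kind of change as that from compound 1 to compound 2, not the same: there the nitrogen's other neighbours were a carbonyl carbon and a saturated ring carbon, here the other neighbour is a carbonyl carbon only. A step of a 1.4-fold lower number from compound 3 to compound 4 (0.14 log units; within the scatter) is expected, set beside a 2.2-fold lower number from compound 1 to compound 2 (0.34 log units; beyond the scatter) but kept smaller, since the earlier step stands alone and sits at a different nitrogen. For compound 4 the estimate in this assay is 18000 nM, with a range from 8000 nM to 45000 nM expected.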

Compound 4, half-maximal inhibitory concentration: 84000 nM
Compound 4: the middle estimate sits 4.7-fold (0.67 log units) below what was measured; measured number outside the range, above it.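

In this assay the new step is a 3.4-fold higher number from compound 3 to compound 4 (0.53 log units; beyond the scatter), which runs the opposite way to the earlier step for the same kind of change. Set side by side, the two steps show that methyl in place of hydrogen on an amide-type nitrogen does not carry over from one core to the other in this series: the same change on two cores in this assay, a 2.2-fold lower number (0.34 log units; beyond the scatter) from compound 1 to compound 2 and a 3.4-fold higher number (0.53 log units; beyond the scatter) from compound 3 to compound 4, 7.3-fold (0.87 log units) apart, beyond the scatter of two such steps They do not show why the two steps part, as the methyl enters at a different nitrogen in each pair and the cores differ as well, and with one pair for each case neither difference can be singled out.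

The compounds shown leave open how a longer chain, such as ethyl in place of the methyl of the methylcarbamoyl group, or a carboxylic acid in place of the carbamoyl group, would read in this assay. They also leave open whether a second methyl on the same nitrogen, giving a dimethylcarbamoyl group, would move the number further in the same direction.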